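One added methyl on the ring of compound 2

The compounds below may be only part of what the source reports. "The series", "measured", "known", "first", "only" and "open" are said of these compounds alone.

Compound 1 `CCN(CCNC(=O)c1cc(Cl)c(N)cc1OC)Cc1cccc(Cl)c1` gives 0.58 mg/kg
Compound 2 `COc1cc(N)c(Cl)cc1C(=O)NCC1CCCN1Cc1ccccc1` gives 1.1 mg/kg

In a functional assay on the whole organism with Rattus norvegicus as the target (a higher number here means that more compound is needed for the effect, a lower number that less compound is needed), compound 2 gives 1.1 mg/kg and compound 1 gives 0.58 mg/kg and these two numbers lie within the usual scatter of each other. Neither compound can therefore be ranked above the other, even though their structures differ in more than one place. Compound 3 `COc1cc(N)c(Cl)cc1C(=O)NCC1CCC(C)N1Cc1ccccc1` comes from compound 2 through a single small edit: methyl in place of hydrogen on a saturated ring carbon. For the measured compounds named here, no measured pair shows what such a change does, so the direction cannot be read from the data, and a wide margin on both sides is needed. Expected here is a 1.1-fold lower number from compound 2 to compound 3 (0.04 log units; within the scatter) and so no step beyond the scatter. For compound 3 the estimated value is 1 mg/kg with an expected range of 0.25 mg/kg to 4.5 mg/kg in this test.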

Compound 3, dose for half-maximal effect: 0.67 mg/kg
Compound 3: middle estimate off by 1.5-fold (0.17 log units), on the high side; the range from low to high includes it.
By their numbers in this assay, from the lowest: compounds 1, 3 and 2 (each within the scatter of the next).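

Methyl in place of hydrogen on this saturated ring carbon gives a 1.6-fold lower number from compound 2 to compound 3 (0.22 log units; within the scatter) in this assay, the first measured pair for this change. At this place, next to the ring nitrogen and next to the ring atom that bears a benzyl group, the five-membered ring therefore carries one extra carbon with no step beyond the scatter, and compound 2 and compound 3 cannot be ranked against each other. No measurement shown here bears on why the number stays within the scatter.

As far as these compounds go, whether a longer chain such as ethyl, or an amine, on this ring carbon would move the number beyond the scatter remains open. So does the effect of a methyl on the other carbons of this ring.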